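Substituting a Sulfonyl Group with a Sulfonamide on the Benzyl Ring

The source may report more compounds than this note shows. Statements on the series, on what has been measured and on what is new or still open speak of the compounds shown alone.

Measured compounds:
- compound 1, `CNc1nc(NCc2ccc(S(C)(=O)=O)cc2)cc(-c2ccccn2)n1`, 185 nM
- compound 2, `CNc1nc(NCc2ccc(Cl)cc2Cl)cc(-c2ccccn2)n1`, 0.5 nM

Of the compounds shown here, two sharing the same core have been measured in a functional assay on HEK293 cells for agonist activity at G-protein coupled receptor 39 (Mus musculus), read by inositol phosphate accumulation; on this read-out lower numbers stand for an effect already at smaller amounts and higher numbers for an effect only at larger amounts of compound. Compound 1 gives 185 nM, the highest number of the two. Compound 2, which carries a differently substituted benzyl group, gives 0.5 nM; the two compounds differ in more than one place, so their values are simply reported side by side, and the gap between them lies well beyond the scatter of this assay.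

Compound 3, `CNc1nc(NCc2ccc(NS(C)(=O)=O)cc2)cc(-c2ccccn2)n1`, has not yet been measured. It is derived from compound 1 by a single change: methanesulfonamido in place of methylsulfonyl on an aromatic carbon. Among the compounds with values here, with no measured pair showing this particular change, the expectation for compound 3 rests on compound 1 alone. The step of a 1.2-fold lower number from compound 1 to compound 3 (0.09 log units; within the scatter) is expected to be small, and is not expected to exceed the scatter in either direction. Compound 3 is therefore estimated at 150 nM, within a range from 40 nM to 600 nM.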

Compound 3, half-maximal effective concentration: 8 nM
The estimate for compound 3 lay 19-fold (1.27 log units) above the measured number; measured number outside the range, below it.
By their numbers in this assay, from the lowest: compound 2; then compound 3; then compound 1.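

Within the data shown here, the pair gives the first single-change reading at this position: in this assay, methanesulfonamido in place of methylsulfonyl on this aromatic carbon gives a 23-fold lower number from compound 1 to compound 3 (1.36 log units; beyond the scatter) and counts as a large step. The read-out therefore responds strongly to a change that keeps the sulfonyl part of the substituent and brings in a nitrogen and a hydrogen-bond donor, which methylsulfonyl lacks. The data offer nothing that explains the size of this step.

The compounds shown leave open whether the nitrogen's hydrogen matters for this step, since no compound carries a methyl group on the sulfonamide nitrogen, and whether a reversed sulfonamide, an acetamido group, an amine or a carboxylic acid on the same carbon would follow compound 3 or compound 1. They also leave open whether a longer chain on the sulfur, such as ethanesulfonamido, would be tolerated, and whether the step seen here would carry over to benzyl groups that also bear chlorine.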